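Trimming the Amine Chain on a Shared Core

The source may hold more compounds than are shown below. What is called first, only, known or untested is meant among the compounds shown, and "the series" means these compounds.

Compound 1 `COCCNc1nc(NCC2CC2)cc(-c2ccccn2)n1` and compound 2 `FC(F)(F)Oc1ccc(CNc2nc(NCC3CC3)cc(-c3ccccn3)n2)cc1` share one core and differ only in the group on one of the amino nitrogens. In a functional assay on HEK293 cells for agonist activity at G-protein coupled receptor 39 (Homo sapiens), read by inositol phosphate accumulation (a lower number here means that less compound is needed, a higher number that more compound is needed for the effect), compound 1 gives 2200 nM, the higher of the two numbers shown, while compound 2 gives 600 nM, a gap beyond the usual scatter. Compound 3 `CNc1nc(NCC2CC2)cc(-c2ccccn2)n1` has not been measured; it differs from compound 1 by hydrogen in place of methoxymethyl on a saturated chain carbon bound to a nitrogen on an aromatic ring. Since the larger group of compound 2 goes with 600 nM, shrinking the group is expected to raise the number somewhat. The expected step from compound 1 to compound 3 is a 1.8-fold higher number from compound 1 to compound 3 (0.26 log units; within the scatter). Compound 3 is estimated at 4000 nM, within 1500 nM to 12000 nM.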

Compound 3, half-maximal effective concentration: 164 nM
For compound 3 the middle estimate is 24-fold (1.39 log units) above the measured one; measured number below the stated range.
By their numbers in this assay, from the lowest: compound 3; then compound 2; then compound 1.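

In this assay, replacing 2-methoxyethyl with methyl on this amino nitrogen gives a 13-fold lower number from compound 1 to compound 3 (1.13 log units; beyond the scatter), so this position responds strongly to the change, and the smallest group shown gives the lowest number. Compound 3 at 164 nM also stands below compound 2 at 600 nM, yet compound 2 lies below compound 1, so the numbers do not follow group size in one direction. Nothing available explains this step. On these data alone, it remains open whether an ethyl group or a bare amino group would lower the number further. A propyl chain would help show whether the step follows the oxygen of 2-methoxyethyl or its chain length.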